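This account rests on a few compounds, and the source may have more. Where it says the series, first, only, none or still open, it means among the compounds named here.

Of the compounds shown here, three have been measured in an ADME assay on CHO cells (Cricetulus griseus) for cytotoxicity, read by MTT assay, with a stated time of 72 h; a higher number here means that more compound is tolerated, a lower number that less compound is tolerated. Compound 1 (`CCOC(=O)c1c(-c2ccccc2)oc2ccc(OCCN3C(=O)C(=O)c4cc(F)ccc43)cc12`) gives 64000 nM, and compound 2 (`CCOC(=O)c1c(-c2ccc(OC)cc2)oc2ccc(OCCCCCCN3C(=O)/C(=N/NC(N)=S)c4cc(F)ccc43)cc12`) gives 128000 nM. Compound 3 (`CCOC(=O)c1c(-c2ccc(F)cc2)oc2ccc(OCCCCCCN3C(=O)/C(=N\O)c4cc(OC)ccc43)cc12`) gives 512000 nM, the highest of the three numbers, with compound 2 and compound 1 both lying below it by more than the scatter. Going by the values given here, these three differ from one another in several places at once, so no measured pair isolates a single change.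

Compound 4 (`CCO/N=C1\C(=O)N(CCCCCCOc2ccc3oc(-c4ccc(F)cc4)c(C(=O)OCC)c3c2)c2ccc(OC)cc21`) departs from compound 3 in one place, turning hydroxy into ethoxy (ethyl in place of hydrogen on an oxygen). Nothing measured shows this change directly. Since compound 3 sits at the top of the set at 512000 nM, a modest fall in the tolerated concentration is expected, not a further rise, though it may barely clear the scatter. The expected step is a 2.0-fold lower number from compound 3 to compound 4 (0.30 log units; within the scatter). For compound 4 the estimated value is 256000 nM, with an expected range from 80000 nM to 700000 nM.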

Compound 4, half-maximal cytotoxic concentration: 256000 nM
Beside the measured number, compound 4's estimate shows no gap at the digits printed; the measured number falls inside the stated range.
By their numbers in this assay, from the lowest: compounds 1, 2, 4 and 3 (each within the scatter of the next, the first and the last beyond it).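

Going by these compounds alone, the first comparison in the set that isolates one change, in this assay, replaces hydrogen with ethyl on an oxygen whose other neighbour is a double-bonded nitrogen, and it gives a 2.0-fold lower number from compound 3 to compound 4 (0.30 log units; within the scatter). The hydroxy and ethoxy forms therefore cannot be told apart at this position in this assay, so capping this oxygen with ethyl has no effect beyond the scatter. Nothing measured here bears on why the result falls this way.

From the compounds shown here alone, it remains open whether a longer chain on this oxygen, or a chain ending in an amine or a carboxylic acid, would also stay within the scatter of compound 3. Also open, going by these compounds, is whether the same change would behave alike with the other groups carried by compound 1 and compound 2, which differ from compound 3 in several places at once.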